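A Methyl Added to Compound 2: What to Expect

This account rests on a few compounds, and the source may have more. Where it says the series, first, only, none or still open, it means among the compounds named here.

Measured compounds:
Compound 1 `Cn1c(SCCC(F)=C(F)F)nc(-c2ccccc2)cc1=O` gives in a functional assay on MCF7 cells (Homo sapiens) for cytotoxicity, read by MTT assay, with a stated time of 48 h (on this read-out higher numbers stand for weaker inhibition and lower numbers for stronger inhibition), only a limit, > 120000 nM.
Compound 2 `N#CC(C#N)=Cc1nccs1` gives in this assay only a limit, > 120000 nM.

Neither measured compound yields a number: each sits at a limit of this assay. Compound 2 therefore stands at the limit of > 120000 nM in this assay, at which 2 of the 2 values shown sit, with nothing shown that sets it apart from compound 1. Among the compounds with values here, no step between two measured compounds that differ in one place is available, so the size of any change can only be guessed.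

Compound 3 `CC(=C(C#N)C#N)c1nccs1` is compound 2 with one small change: methyl in place of hydrogen on a double-bonded chain carbon bound to an aromatic carbon and a double-bonded chain carbon. In this assay no change beyond the usual scatter is expected from so small an addition, and the step that the limit leaves unreadable from compound 2 to compound 3 is expected to be essentially flat. Compound 3 is expected to sit again at the limit, estimated at 150000 nM with a range from 60000 nM to 400000 nM.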

Compound 3, half-maximal inhibitory concentration: 110000 nM
Compound 3: the middle estimate sits 1.4-fold (0.13 log units) above what was measured; the measured number falls inside the stated range.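

With compound 3, this assay yields its first actual number among the compounds shown, 110000 nM. Compound 1 and compound 2 gave only limits. Methyl in place of hydrogen at this double-bonded chain carbon gives an at least 1.0-fold lower number from compound 2 to compound 3 (0.03 log units; that floor lies within the scatter), so the change does not push the compound past the limit, but it shows no gain beyond the scatter either. Compound 2 has only a limit, so the true size of the step stays unknown, and the reading of compound 3 remains close to where most of the series sits: the limit of > 120000 nM in this assay, at which 2 of the 3 values shown sit.

The compounds shown leave open whether a larger group at this same place, such as an ethyl chain or an amine, would clearly move the number in either direction. They also leave open what would happen if a carboxylic acid took the place of a nitrile.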